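A shorter chain and its expected effect on inhibition

This account rests on a few compounds, and the source may have more. Where it says the series, first, only, none or still open, it means among the compounds named here.

Compound 1 `NC(=O)CCn1nc(-c2ccccc2)ccc1=O`: -2.8%
Compound 2 `C/N=C(/S)CCCCCn1nc(-c2ccccc2)ccc1=O`: 92.3%

In a functional assay on the whole organism (stomach) for inhibition, with Rattus norvegicus as the target, at a dose of 100 mg/kg by the intraduodenal route (a higher number here means more inhibition at the dose given (going by the name of the read-out), a lower number less inhibition), compound 1 gives -2.8%, while compound 2 gives 92.3%. Going by the values given here, compound 2 thus stands highest of the two numbers; its only neighbour is compound 1, and the step between them is a number 95.1 percentage points higher from compound 1 to compound 2 (beyond the scatter). That step changes the chain length and the end group at once, so the two parts of it cannot be told apart.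

Compound 3 `N=C(S)CCCCn1nc(-c2ccccc2)ccc1=O` has not yet been measured. a group of 3 heavy atoms (1 carbon, 1 nitrogen, 1 sulfur; no ring) in place of a group of 5 heavy atoms (3 carbon, 1 nitrogen, 1 sulfur; no ring), on a saturated chain carbon, four bonds along the chain from an aromatic nitrogen The end group still holds sulfur, but the chain is shorter and the group itself is smaller. Among the compounds with values here, no measured step matches this change, so the expectation rests on a loose reading of the one step known. Because compound 2 reaches 92.3% with a related group, the number for compound 3 is expected to stay well above that of compound 1. A downward step of moderate size is nevertheless expected: a number 32.3 percentage points lower from compound 2 to compound 3 (beyond the scatter). Compound 3 is estimated at 60%, within a range from 20% to 95%.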

Compound 3, a percentage reported as inhibition, in the whole organism at one dose (the size of the read-out at that dose, not a potency): 33.8%
Compound 3: middle estimate off by 26.2 percentage points, on the high side; the range from low to high includes it.
By their numbers in this assay, from the lowest: compound 1; then compound 3; then compound 2.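

Going from the group of 5 heavy atoms to the group of 3 heavy atoms, on a saturated chain carbon, four bonds along the chain from an aromatic nitrogen, gives a number 58.5 percentage points lower from compound 2 to compound 3 (beyond the scatter) in this assay, so the high inhibition does not survive this trimming of the chain end, even though the sulfur stays and the count of hydrogen-bond donors goes from 1 to 2. Compound 3 still keeps a good part of the inhibition, with a number 36.6 percentage points higher from compound 1 to compound 3 (beyond the scatter), so among these three compounds the read-out takes an intermediate level and is not simply present or absent. No measured property of these compounds accounts for either step, and nothing here gives a reason for them.

As far as these compounds go, both steps alter chain length and end group together, so the share of each remains unknown; the end group of compound 3 on the longer chain of compound 2, or the end group of compound 2 on the shorter chain of compound 3, would pull the two apart. Also open, from the compounds shown here alone, is how an even longer chain would behave, or the same chains ending in an amide, an amine or a carboxylic acid.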